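Pentafluorosulfanyl in place of dimethylamino on the benzamide

The compounds below may be only part of what the source reports. "The series", "measured", "known", "first", "only" and "open" are said of these compounds alone.

Measured compounds:
compound 1, `CC(C)(C)c1ccc(C(=O)NCc2ccc(NS(=O)(=O)C(F)(F)F)cc2Cl)cc1`: 17 mL.min-1.g-1
compound 2, `CC(C)(C)c1ccc(C(=O)NCc2ccc(NS(C)(=O)=O)cc2F)cc1`: 47 mL.min-1.g-1
compound 3, `CN(C)c1ccc(C(=O)NCc2ccc(NS(C)(=O)=O)cc2Cl)cc1`: 25 mL.min-1.g-1

All three values come from an ADME assay on microsomes from liver (Rattus norvegicus, strain Sprague-Dawley) for metabolic stability, read by HPLC, using NADPH, with stated times of 5 min and 60 min, tested at 10 uM; a lower number here means slower removal, a higher number faster removal of the compound. Among these three numbers compound 3 stands second highest. Its nearest neighbour is compound 1, which lies within the scatter of repeated measurements; the furthest is compound 2, and that gap, too, lies within the scatter. Among the measured compounds shown here, none of the three measured compounds differs from another in a single place, so no measured step is available to calibrate any change on this series. The spread of the three numbers is itself narrow.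

Compound 4, `CS(=O)(=O)Nc1ccc(CNC(=O)c2ccc(S(F)(F)(F)(F)F)cc2)c(Cl)c1`, has not yet been run in this assay. Relative to compound 3 the change is: a group of 6 heavy atoms (5 fluorine, 1 sulfur; no ring) in place of a group of 3 heavy atoms (2 carbon, 1 nitrogen; no ring), on an aromatic carbon.

For the measured compounds named here, with no measured step for guidance, the expectation rests only on the narrow band of the three measured values. The step of a 2.1-fold lower number from compound 3 to compound 4 (0.32 log units; beyond the scatter) is expected to be downward and modest, near the edge of the scatter rather than clearly beyond it. Compound 4 is accordingly estimated at 12 mL.min-1.g-1 in this assay, with a range running from 5 mL.min-1.g-1 to 28 mL.min-1.g-1.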

Compound 4, intrinsic clearance in microsomes: 9.8 mL.min-1.g-1
For compound 4 the middle estimate is 1.2-fold (0.09 log units) above the measured one, and the stated range covers the measured number.
By their numbers in this assay, from the lowest: compounds 4, 1, 3 and 2 (each within the scatter of the next, the first and the last beyond it).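

In this assay, among the compounds shown here, the exchange of dimethylamino for the group of 5 fluorine and 1 sulfur, on an aromatic carbon para to a large group, gives a 2.6-fold lower number from compound 3 to compound 4 (0.41 log units; beyond the scatter) and is the only single-place step available. It shows that a change at this position alone, with the rest of the core held constant, can move the clearance read-out beyond the scatter, though the step is modest; the three earlier compounds, which differ from one another in more than one place, could not show this. No measurement on hand explains the size or direction of the step.

Still open, going by these compounds, is how other groups at this position would compare on the same core, among them tert-butyl, which so far appears only with other changes elsewhere in the molecule, as well as a nitrile, a methoxy group or a carboxylic acid. Also open, on these data alone, is whether the same exchange gives a step of similar direction and size when the chlorine is replaced by fluorine or the methanesulfonamide by its trifluoromethyl counterpart.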